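The source may hold more compounds than are shown below. What is called first, only, known or untested is meant among the compounds shown, and "the series" means these compounds.

Measured compounds:
Compound 1 `O=C(OC1CCCCC1)N1CCC(c2nc(-c3ccc4ccccc4n3)no2)CC1` gives 580 nM in a functional assay on Shh Light II cells (Mus musculus) for inhibition, read by a luciferase reporter; a higher number here means a weaker inhibitor, a lower number a stronger inhibitor.
Compound 2 `C[C@H]1C[C@H](c2nc(-c3ccc4ccccc4n3)no2)CCN1C(=O)Nc1ccccc1Cl` gives 900 nM in this assay.

Of the two numbers, compound 1 has the lower one, but its nearest neighbour is compound 2, and the gap between them lies within the scatter, so neither can be called the stronger inhibitor on these data. Compound 3 `O=C(NC1CCCCC1)N1CCC(c2nc(-c3ccc4ccccc4n3)no2)CC1` has not yet been measured. It differs from compound 1 in one place: cyclohexylamino in place of cyclohexyloxy on a carbonyl carbon. Going by the values given here, no measured pair shows this change, so the size of the step rests on expectation alone. The change from cyclohexyloxy to cyclohexylamino keeps the count of heavy atoms and the ring, and exchanges an acceptor for a donor; such a change is expected to move the number in this assay only modestly, if at all, toward the lower side. Compound 3 is therefore estimated at 400 nM, within 120 nM to 1300 nM, a step of a 1.5-fold lower number from compound 1 to compound 3 (0.16 log units; within the scatter) that is expected to stay close to the scatter.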

Compound 3, half-maximal inhibitory concentration: 57 nM
Estimate against measurement, compound 3: 7.0-fold (0.85 log units) above; the measured number lies below the stated range.
By their numbers in this assay, from the lowest: compound 3; then compounds 1 and 2 (each within the scatter of the next).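

In this assay, the change from cyclohexyloxy to cyclohexylamino on a carbonyl carbon gives a 10-fold lower number from compound 1 to compound 3 (1.01 log units; beyond the scatter). This is the first sign that the group at this place is not interchangeable, since the two compounds already shown differ at more than one place and their numbers lie within the scatter. Here the ring and the heavy-atom count stay the same, and the exchange of one oxygen for one nitrogen, with a hydrogen-bond donor entering and an acceptor leaving, is enough to produce a large step, though nothing shown here gives a measured reason for it.

On these data alone, it remains open whether methyl(cyclohexyl)amino, which has no amide hydrogen, would keep this low number. Also open, as far as these compounds go, is whether the step carries over to cyclopentylamino or phenylamino on the same carbonyl carbon.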